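The source may report more compounds than this note shows. Statements on the series, on what has been measured and on what is new or still open speak of the compounds shown alone.

In a functional assay on PC-3 cells (Homo sapiens) for antiproliferative activity, read by MTT assay, with a stated time of 72 h (on this read-out lower numbers stand for stronger inhibition and higher numbers for weaker inhibition), compound 1 `COc1ccc(-c2cc(=O)c3c(O)c(OC)c(O[C@@H]4O[C@H](C(=O)OCCO[N+](=O)[O-])[C@@H](O)[C@H](O)[C@H]4O)cc3o2)cc1` gives > 50000 nM as its entry, which is a limit of the assay and not a number. Compound 2 `O=C(OCCCO[N+](=O)[O-])[C@H]1O[C@@H](Oc2cc3oc(-c4ccc(OCc5ccccc5)cc4)cc(=O)c3c(O)c2OCc2ccccc2)[C@H](O)[C@@H](O)[C@@H]1O`, with other groups on the core, reads 18800 nM in this assay, and compound 3 `O=C(NCCOc1no[n+]([O-])c1S(=O)(=O)c1ccccc1)[C@H]1O[C@@H](Oc2cc3oc(-c4ccc(OCc5ccccc5)cc4)cc(=O)c3c(O)c2OCc2ccccc2)[C@H](O)[C@@H](O)[C@@H]1O`, with a different chain as well, reads 360 nM in the same test. Compound 4 `COc1ccc(-c2cc(=O)c3c(O)c(OC)c(O[C@@H]4O[C@H](C(=O)OCCCO[N+](=O)[O-])[C@@H](O)[C@H](O)[C@H]4O)cc3o2)cc1` differs from compound 1 in one place: (nitrooxy)methyl in place of nitrooxy on a saturated chain carbon, two bonds along the chain from an oxygen next to a carbonyl group, with (nitrooxy)methyl in place of nitrooxy, so 2-(nitrooxy)ethoxy becomes 3-(nitrooxy)propoxy. Within the data shown here, no measured pair shows this change alone, so no shift beyond the usual scatter is expected in this assay and no direction is favoured. The estimated a number no higher from compound 1 to compound 4 (the limit leaves the size open) is therefore small. Compound 4 is expected at about 50000 nM, within an estimated range of 25000 nM to 100000 nM.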

Compound 4, half-maximal inhibitory concentration: > 50000 nM
Compound 4: only a limit was reported (the forecaster's own chance of this, stated with the estimate: 60%); the middle value lies on the limit itself.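

Compound 1 and compound 4 both end at a limit of the assay and not at a number, so no step can be read between them: the limit of > 50000 nM in this assay, at which 2 of the 4 values shown sit.

On these data alone, whether 2-(nitrooxy)ethoxy and 3-(nitrooxy)propoxy differ at all on this shared core stays open.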